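The compounds below may be only part of what the source reports. "The series", "measured", "known", "first", "only" and "open" are said of these compounds alone.

Measured so far:
- compound 1 `CC(=O)c1ncc([C@@H](O)[C@H](O)[C@H](O)CO)s1`: 0.9 h
- compound 2 `CC(F)(F)c1nc([C@@H](O)[C@H](O)[C@H](O)CO)c[nH]1`: 1 h
- compound 3 `OC[C@@H](O)[C@@H](O)[C@H](O)c1c[nH]c(C(F)(F)C(F)(F)F)n1`: 1.7 h

All three were measured in an ADME assay on the whole organism (strain 129/SvEvBrd x C57BL/6) for metabolic stability, with Mus musculus as the target; a lower number here means that the compound disappears faster, a higher number that the compound lasts longer. Compound 2, at 1 h, has no measured neighbour beyond the scatter, since compound 1 and compound 3 both lie within it.

The next step leads to compound 4 `OC[C@@H](O)[C@@H](O)[C@H](O)c1c[nH]c(-c2ncc[nH]2)n1`. The change is 1H-imidazol-2-yl in place of 1,1-difluoroethyl on an aromatic carbon, in words 1H-imidazol-2-yl in place of 1,1-difluoroethyl on an aromatic carbon.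

Going by the values given here, only one measured step touches this group: a 1.7-fold higher number from compound 2 to compound 3 (0.23 log units; within the scatter). It stays within the scatter, but it only alters a saturated chain. Among the compounds with values here, no measured compound carries the 1H-imidazol-2-yl group, so that step gives weak guidance and no direction for a change to a ring. The narrow spread of the three values offers no basis for a large move either.

The estimated move is no change at the digits printed from compound 2 to compound 4 (within the scatter), and nothing beyond the scatter is expected in this assay. For compound 4 the expected half-life is 1 h, with an estimated range of 0.4 h to 2.5 h.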

Compound 4, half-life: 3.2 h
For compound 4 the middle estimate is 3.2-fold (0.51 log units) below the measured one; measured number above the stated range.
By their numbers in this assay, from the lowest: compounds 1, 2, 3 and 4 (each within the scatter of the next, the first and the last beyond it).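

In this assay the aromatic carbon between two ring nitrogen atoms proves able to carry a change that moves the half-life beyond the scatter: replacing 1,1-difluoroethyl with 1H-imidazol-2-yl gives a 3.2-fold higher number from compound 2 to compound 4 (0.51 log units; beyond the scatter), whereas the earlier change within the chain gave only a 1.7-fold higher number from compound 2 to compound 3 (0.23 log units; within the scatter). This position therefore accepts a five-membered aromatic ring with 1 hydrogen-bond donor and 1 hydrogen-bond acceptor in place of a chain with neither, and the half-life does not fall. No measurement at hand accounts for the gain.

Open, going by these compounds, is whether a phenyl ring, which has no ring nitrogen, or an imidazole with a methyl group on its ring nitrogen would give a similar half-life. Also open, on these data alone, is whether an amine or a carboxylic acid would be tolerated at this position.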